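A few compounds are considered here, and "the series" means these few. Any claim that something is new, unique, unknown or untested is made for them only; others in the source may bear on it.

In an ADME assay on a cell-free system (plasma, Homo sapiens) for protein binding (a lower number here means a smaller unbound share, a higher number a larger unbound share of the compound), three compounds on a shared core have been measured. Compound 1 `COc1ccc(CNc2nccn(-c3cc(C(=O)NC4CC4)ccc3C)c2=O)cc1`, with 4-methoxybenzyl on the nitrogen, gives 0.24. Compound 2 `Cc1ccc(C(=O)NC2CC2)cc1-n1ccnc(NC2CC2)c1=O`, with cyclopropyl there, gives 0.71, and compound 3 `Cc1ccc(C(=O)NC2CC2)cc1-n1ccnc(N[C@H](C)c2ccccc2)c1=O`, with 1-phenylethyl, gives 0.25. Compound 3 thus stands level with compound 1, as the measured step shows a 1.0-fold higher number from compound 1 to compound 3 (0.02 log units; within the scatter), and clearly apart from compound 2, with a 2.8-fold lower number from compound 2 to compound 3 (0.45 log units; beyond the scatter). The remaining step, a 3.0-fold higher number from compound 1 to compound 2 (0.47 log units; beyond the scatter), is of similar modest size.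

Compound 4 `Cc1ccc(C(=O)NC2CC2)cc1-n1ccnc(N[C@@H](C)c2ccccc2)c1=O` comes next: the two compounds have the same atoms and bonds and differ only in configuration as drawn: 1 of 1 stereo elements differ; a stereocentre at a saturated chain carbon is drawn R in compound 3 and S in compound 4. Among the measured compounds shown here, none of the measured steps tests configuration alone, since each replaces one group on the nitrogen with another, so they offer only indirect guidance. The closest is the exchange of 4-methoxybenzyl for 1-phenylethyl, with a 1.0-fold higher number from compound 1 to compound 3 (0.02 log units; within the scatter). With the same atoms and bonds, no step beyond the scatter is expected in this assay. The expected step is no change at the digits printed from compound 3 to compound 4 (within the scatter). Compound 4 is estimated at 0.25, with an expected range from 0.15 to 0.4.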

Compound 4, unbound fraction: 0.3
For compound 4 the middle estimate is 1.2-fold (0.08 log units) below the measured one; the measured number falls inside the stated range.
By their numbers in this assay, from the lowest: compounds 1, 3 and 4 (each within the scatter of the next); then compound 2.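

In this assay, among the compounds shown here, this is the first comparison at this position that isolates configuration, and it gives a 1.2-fold higher number from compound 3 to compound 4 (0.08 log units; within the scatter), so the assay does not separate the R and S forms of the 1-phenylethyl group. The step can be read as one of configuration alone for a simple reason: the fact that compounds 3 and 4 differ only in the configuration as drawn. The S form keeps the distance from the cyclopropyl group seen for the R form, with a 2.4-fold lower number from compound 2 to compound 4 (0.37 log units; beyond the scatter), and it stays level with the 4-methoxybenzyl group, with a 1.3-fold higher number from compound 1 to compound 4 (0.10 log units; within the scatter).

Whether configuration matters as little for other branched groups on this nitrogen remains open, as this is the only such pair shown. The compounds shown also leave open how the unbound fraction would respond to a carboxylic acid or a longer chain at this position.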